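This account rests on a few compounds, and the source may have more. Where it says the series, first, only, none or still open, it means among the compounds named here.

In a functional assay on PANC-1 cells (Homo sapiens) for inhibition, read by MTT assay, with a stated time of 24 h (on this read-out higher numbers stand for weaker inhibition and lower numbers for stronger inhibition), compound 1 `CC1(C)[C@H]2CC[C@]1(C)N(Cc1cn(-c3cccc(F)c3)nn1)C(=O)C2` gives 220 nM, compound 2 `CC1(C)[C@H]2CC[C@]1(C)N(Cc1cn(-c3cccc(Br)c3)nn1)C(=O)C2` gives 90 nM and compound 3 `COc1ccc(-n2cc(CN3C(=O)C[C@@H]4CC[C@@]3(C)C4(C)C)nn2)cc1` gives 330 nM. The step of a 1.5-fold higher number from compound 1 to compound 3 (0.18 log units; within the scatter) stays within the scatter, whereas the step of a 3.7-fold higher number from compound 2 to compound 3 (0.56 log units; beyond the scatter) goes beyond it, so compound 3 shares the weak end of this small set with compound 1. Compound 4 `Cc1cccc(-n2cc(CN3C(=O)C[C@@H]4CC[C@@]3(C)C4(C)C)nn2)c1` differs from compound 3 by 3-methylphenyl in place of 4-methoxyphenyl on an aromatic nitrogen, with 3-methylphenyl in place of 4-methoxyphenyl on an aromatic nitrogen. Those same two steps are the closest guides, since each swaps that group for another substituted phenyl. The new group resembles the 3-fluorophenyl and 3-bromophenyl groups by name, and the step between those, a 2.4-fold lower number from compound 1 to compound 2 (0.39 log units; beyond the scatter), is modest. A modest fall in the number is therefore expected, and the expected change is a 2.2-fold lower number from compound 3 to compound 4 (0.34 log units; beyond the scatter). Compound 4 is estimated at 150 nM, with an expected range from 70 nM to 320 nM.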

Compound 4, half-maximal inhibitory concentration: 240 nM
Estimate against measurement, compound 4: 1.6-fold (0.20 log units) below, and the stated range covers the measured number.
By their numbers in this assay, from the lowest: compound 2; then compounds 1, 4 and 3 (each within the scatter of the next).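

On the aromatic nitrogen, swapping 4-methoxyphenyl for 3-methylphenyl gives no real separation (a 1.4-fold lower number from compound 3 to compound 4 (0.14 log units; within the scatter)), and methyl reads the same as fluoro on that aromatic carbon (a 1.1-fold higher number from compound 1 to compound 4 (0.04 log units; within the scatter)). Bromo, by contrast, stands apart from methyl (a 2.7-fold higher number from compound 2 to compound 4 (0.43 log units; beyond the scatter)), so compound 2 is now the only compound separated from all the others, while compounds 1, 3 and 4 form one group. Nothing measured here explains this result. Still open, from the compounds shown here alone, is how an amine or a carboxylic acid in place of that methyl would read, and whether chloro or iodo would side with bromo or with the other three.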